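Amide series, fluoro for methyl: working notes

The source may hold more compounds than are shown below. What is called first, only, known or untested is meant among the compounds shown, and "the series" means these compounds.

Compound 1 `C/C=C/C(=O)Nc1cccc(-c2nc3ccccc3s2)c1`: in an ADME assay on HEK293 cells (Homo sapiens) for inhibition, with a stated time of 72 h (a lower number here means that less compound is needed, a higher number that more compound is needed for the effect), compound 1 gives > 25000 nM, a limit of the assay.
Compound 2 `O=C(Nc1cccc(-c2nc3ccccc3s2)c1)c1cc([N+](=O)[O-])cnc1Cl`: in this assay compound 2 gives > 25000 nM, also a limit.
Compound 3 `Cc1ccc(-c2nc3ccccc3s2)cc1NC(=O)c1cnccc1Cl`: in this assay compound 3 gives > 25000 nM, again a limit.

Among the compounds with values here, compound 3 thus stands at the limit of > 25000 nM in this assay, at which 3 of the 3 values shown sit; no number below that limit is known for any of the three, and no step between measured compounds can be drawn.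

Compound 4 `O=C(Nc1cc(-c2nc3ccccc3s2)ccc1F)c1cnccc1Cl` differs from compound 3 by fluoro in place of methyl on an aromatic carbon. With nothing in the measured set to size such a change, the expected step in this assay from compound 3 to compound 4 is a number no higher from compound 3 to compound 4 (the limit leaves the size open), none beyond the scatter. Compound 4 is therefore estimated at 25000 nM, within 8000 nM to 80000 nM, most likely reported again only as a limit.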

Compound 4, half-maximal effective concentration: > 25000 nM
Compound 4 gave a limit, no number; the forecaster's own chance of this, stated with the estimate: 80%; the middle value sits exactly at the limit.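

No step can be read from compound 3 to compound 4 in this assay, since both values are limits: the limit of > 25000 nM in this assay, at which 4 of the 4 values shown sit.
The compounds shown leave open what fluoro in place of methyl does here, and which change would give a number rather than a limit.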